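The compounds below may be only part of what the source reports. "The series", "measured", "known", "first", "only" and "open" are said of these compounds alone.

Measured compounds:
compound 1, `CN(C)C(=S)N/N=C/c1cc2cccnc2s1`: > 100000 nM in a functional assay on HL-60 cells (Homo sapiens) for antiproliferative activity, read by sulforhodamine B assay, with a stated time of 72 h; a lower number here means a stronger inhibitor, a higher number a weaker inhibitor
compound 2, `Cc1ccc(NC(=S)N/N=C/c2ccc3ccccc3n2)cc1`: 78300 nM

Compound 1 does not yield a number in this assay; its entry is a limit of the assay. Going by the values given here, compound 2 stands as the only numerical value shown; the other entry is the limit of > 100000 nM in this assay, at which 1 of the 2 values shown sits. Compound 3, `S=C(N/N=C/c1ccc2ccccc2n1)Nc1ccccc1`, has not yet been measured in this assay. It differs from compound 2 in one place: hydrogen in place of methyl on an aromatic carbon. Among the compounds with values here, no step between two measured compounds is available to calibrate this change, so any expectation rests on compound 2 alone. The step from compound 2 to compound 3 is expected to be a 1.1-fold higher number from compound 2 to compound 3 (0.04 log units; within the scatter), a change judged as none beyond the usual scatter, in no firm direction. Compound 3 is therefore estimated at 85000 nM, with a range from 30000 nM to 250000 nM, and a fair chance that the assay reports only a limit.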

Compound 3, half-maximal inhibitory concentration: 9130 nM
Beside the measured number, compound 3's estimate is 9.3-fold (0.97 log units) above it, outside the stated range (below it).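

In this assay, going from 4-methylphenyl to phenyl gave an 8.6-fold lower number from compound 2 to compound 3 (0.93 log units; beyond the scatter), a step beyond the usual scatter. This shows that the aromatic carbon para to a large group is not a silent position on the shared core, and that of these two compounds the one carrying hydrogen there is the stronger inhibitor. Compound 1 offers no comparison, as it differs from the others in more than one place and its entry is only a limit of the assay: the limit of > 100000 nM in this assay, at which 1 of the 3 values shown sits.

A single step at a single position cannot show whether any group there weakens the compounds or methyl alone does. As far as these compounds go, how a fluorine, a methoxy group or an amine at the same carbon would read in this assay remains open, as does whether the change carries over to the core of compound 1.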